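A few compounds are considered here, and "the series" means these few. Any claim that something is new, unique, unknown or untested is made for them only; others in the source may bear on it.

Compounds measured:
compound 1 `O/N=C(/Nc1cccc(F)c1)c1ccc2occc2c1`, 20000 nM
compound 2 `O/N=C(/Nc1ccc(Cl)c(F)c1)c1ccc2occc2c1`, 10300 nM
compound 3 `O/N=C(/Nc1cccc(-c2ccccc2)c1)c1ccc2occc2c1`, 11900 nM

In an assay on tissue (HeLa cells) for inhibition of Indoleamine 2,3-dioxygenase 1 (Homo sapiens), read by spectrophotometry (a lower number here means a stronger inhibitor, a higher number a weaker inhibitor), compound 1 gives the highest of the three numbers, yet its gaps to compound 2 (a 1.9-fold lower number from compound 1 to compound 2 (0.29 log units; within the scatter)) and to compound 3 (a 1.7-fold lower number from compound 1 to compound 3 (0.23 log units; within the scatter)) are both within the scatter, so the three stand level. Compound 4 `O/N=C(/Nc1cccc(F)c1)c1ccc2oc(-c3ccccc3)cc2c1` differs from compound 1 by phenyl in place of hydrogen on an aromatic carbon. Neither measured step touches this part of the shared core; both alter the other aromatic ring, and both stayed within the scatter. Nothing shown therefore points to a change beyond the scatter in this assay for this step. Compound 4 is accordingly expected to give 20000 nM, between 6000 nM and 60000 nM, a step of no change at the digits printed from compound 1 to compound 4 (within the scatter).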

Compound 4, half-maximal inhibitory concentration: 10600 nM
Compound 4: the middle estimate sits 1.9-fold (0.28 log units) above what was measured; measured number inside the range.
By their numbers in this assay, from the lowest: compounds 2, 4, 3 and 1 (each within the scatter of the next).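

In this assay, going by these compounds alone, phenyl in place of hydrogen on an aromatic carbon next to the ring oxygen gives a 1.9-fold lower number from compound 1 to compound 4 (0.28 log units; within the scatter), so this position, which the earlier steps left untouched, carries a phenyl without a change beyond the scatter. No measurement available bears on why this step stays so small. On these data alone, whether an amine or a carboxylic acid at this position would move the number beyond the scatter stays open, as does whether phenyl here would behave the same alongside the chloro group of compound 2.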